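Swapping Aryl Groups on a Sulfonamide Antiproliferative

A few compounds are considered here, and "the series" means these few. Any claim that something is new, unique, unknown or untested is made for them only; others in the source may bear on it.

Compound 2 `Cc1ccc(NS(=O)(=O)c2ccc(N3CCNC3=O)cc2)cc1C` carries a 3,4-dimethylphenyl group on its sulfonamide nitrogen. In a functional assay on HT-29 cells (Homo sapiens) for antiproliferative activity, read by sulforhodamine B assay, with a stated time of 48 h (on this read-out higher numbers stand for weaker inhibition and lower numbers for stronger inhibition), compound 2 gives 230 nM, the higher of the two plain numbers in hand. Compound 1 `O=C1NCCN1c1ccc(S(=O)(=O)Nc2ccc3[nH]ccc3c2)cc1` gives 130 nM in this assay, and the two numbers sit within the usual scatter of each other, so they cannot be told apart. Compound 3 `CC(C)(C)c1cc(NS(=O)(=O)c2ccc(N3CCNC3=O)cc2)cc(C(C)(C)C)c1` reaches only a limit in this assay, reported as > 1000 nM. Compound 4 `COc1cccc(NS(=O)(=O)c2ccc(N3CCNC3=O)cc2)c1` has not yet been measured; it differs from compound 2 by 3-methoxyphenyl in place of 3,4-dimethylphenyl on a sulfonamide nitrogen. For the measured compounds named here, no measured pair isolates such a change, so the expected step of a 1.1-fold higher number from compound 2 to compound 4 (0.04 log units; within the scatter) is estimated to be none beyond the scatter. Compound 4 is therefore expected to give about 250 nM in this assay, between 100 nM and 700 nM.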

Compound 4, half-maximal inhibitory concentration: 120 nM
For compound 4 the middle estimate is 2.1-fold (0.32 log units) above the measured one; low and high end bracket the measured number.
By their numbers in this assay, from the lowest: compounds 4, 1 and 2 (each within the scatter of the next). At a limit, above all of these: compound 3.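

Putting 3-methoxyphenyl in place of 3,4-dimethylphenyl on the sulfonamide nitrogen leaves the two compounds indistinguishable in this assay (a 1.9-fold lower number from compound 2 to compound 4 (0.28 log units; within the scatter)). For the compounds shown here, at this position, then, a ring carrying an oxygen-linked group reads the same as one carrying only carbon groups, which the earlier compounds did not show. Nothing measured here explains this result.

Still open, from the compounds shown here alone, is how a bare phenyl group would compare, and how a ring bearing an amine or a carboxylic acid would read at this position.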